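The source may hold more compounds than are shown below. What is called first, only, known or untested is meant among the compounds shown, and "the series" means these compounds.

Measured compounds in an ADME assay, in phosphate buffer, at 28 degrees C, at pH 7.0; on this read-out higher numbers stand for a longer-lived compound and lower numbers for a shorter-lived compound:
compound 1 `C[C@@H](O)[C@H]1C(=O)N2C(C(=O)O)=C(C(C)(C)C)O[C@H]12`, half-life 8.1 h
compound 2 `CC(C)(C)C1=C(C(=O)O)N2C(=O)[C@H]([C@H](O)c3ccncc3)[C@H]2O1`, half-life 6.4 h

Compound 2 holds the lower of the two numbers in this assay; its nearest neighbour is compound 1, and the step of a 1.3-fold lower number from compound 1 to compound 2 (0.10 log units; within the scatter) lies within the scatter, so the two compounds are read as indistinguishable here.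

Compound 3 `CC(C)(C)C1=C(C(=O)O)N2C(=O)[C@H]([C@H](O)CCc3ccccc3)[C@H]2O1` differs from compound 2 in one place: phenethyl in place of pyridin-4-yl on a saturated chain carbon bound to an oxygen on a saturated carbon and a saturated ring carbon. For the measured compounds named here, the only measured step that touches this place is a 1.3-fold lower number from compound 1 to compound 2 (0.10 log units; within the scatter), an exchange at the same carbon in which the number stayed within the scatter. Going by the values given here, no measured step puts phenethyl at this place, so the expectation rests on that single step alone. Compound 3 is therefore expected to stay close to compound 2, with no step beyond the scatter in either direction, the expected step being a 1.0-fold higher number from compound 2 to compound 3 (0.01 log units; within the scatter). The estimate for compound 3 in this assay is 6.5 h, with a range from 3.2 h to 13 h.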

Compound 3, half-life: 21 h
Compound 3: middle estimate off by 3.2-fold (0.51 log units), on the low side; the measured number lies above the stated range.
By their numbers in this assay, from the lowest: compounds 2 and 1 (each within the scatter of the next); then compound 3.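

In this assay, the place on a saturated chain carbon bound to an oxygen on a saturated carbon and a saturated ring carbon turns out to respond to the group it carries, which the exchange of methyl for pyridin-4-yl did not show: phenethyl in place of pyridin-4-yl gives a 3.3-fold higher number from compound 2 to compound 3 (0.52 log units; beyond the scatter) on this read-out. The comparison with the methyl compound points the same way, with a 2.6-fold higher number from compound 1 to compound 3 (0.41 log units; beyond the scatter) for benzyl in place of hydrogen on the chain. Both steps are modest, but phenethyl separates from the other two groups, which stay within the scatter of each other. No measurement here bears on what lies behind this difference.

Phenethyl and pyridin-4-yl differ in both chain and ring, so the contributions of the two-carbon link and the ring nitrogen remain unseparated. A plain benzyl, a longer chain ending in phenyl, or a phenethyl carrying an amine would help to divide them.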